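The source may hold more compounds than are shown below. What is called first, only, known or untested is meant among the compounds shown, and "the series" means these compounds.

Compound 1 `Cc1ccc(-c2nc(N)c3cc(Cc4ccccc4)sc3n2)o1` gives 298 nM in a functional assay on CHO-K1 cells for antagonist activity at adenosine receptor A1 (Homo sapiens), read by a beta-galactosidase reporter and cAMP accumulation, with stated times of 15 min and 6 h; a higher number here means a weaker inhibitor, a lower number a stronger inhibitor.
Compound 2 `CCc1ccc(-c2nc(N)c3cc(Cc4ccccc4)sc3n2)o1` gives 223 nM in this assay.
Compound 3 `Nc1nc(-c2ncco2)nc2sc(Cc3ccccc3)cc12` gives 310 nM in this assay.

Compound 3 has the highest of the three numbers, but the gap to its nearest neighbour, compound 1, and to its furthest, compound 2, both lie within the scatter, so no order among the three can be drawn from these values. Compound 4 `Cc1csc(-c2nc(N)c3cc(Cc4ccccc4)sc3n2)n1` is obtained from compound 3 by the change (4-methyl-1,3-thiazol-2-yl in place of 1,3-oxazol-2-yl on an aromatic carbon). The measured steps that bear on this are the two earlier exchanges of the group on that same aromatic carbon, a 1.0-fold higher number from compound 1 to compound 3 (0.02 log units; within the scatter) and a 1.4-fold higher number from compound 2 to compound 3 (0.14 log units; within the scatter), together with the smaller alteration within that group, a 1.3-fold lower number from compound 1 to compound 2 (0.13 log units; within the scatter). Each of these left the number within the scatter, and none of them points in a consistent direction. On that basis the exchange of the 1,3-oxazol-2-yl group for the 4-methyl-1,3-thiazol-2-yl group is expected to produce no step beyond the scatter in this assay. Compound 4 is therefore estimated at 260 nM, with a range from 110 nM to 620 nM. This estimate corresponds to a 1.2-fold lower number from compound 3 to compound 4 (0.08 log units; within the scatter), which is expected to stay within the scatter.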

Compound 4, inhibition constant: 1490 nM
Compound 4: the middle estimate sits 5.7-fold (0.76 log units) below what was measured, outside the stated range (above it).
By their numbers in this assay, from the lowest: compounds 2, 1 and 3 (each within the scatter of the next); then compound 4.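

At the aromatic carbon between two ring nitrogen atoms, 4-methyl-1,3-thiazol-2-yl in place of 1,3-oxazol-2-yl gives a 4.8-fold higher number from compound 3 to compound 4 (0.68 log units; beyond the scatter) in this assay, and the same group gives a 6.7-fold higher number from compound 2 to compound 4 (0.82 log units; beyond the scatter) in place of 5-ethylfuran-2-yl and a 5.0-fold higher number from compound 1 to compound 4 (0.70 log units; beyond the scatter) in place of 5-methylfuran-2-yl. Within the data shown here, the earlier exchanges among 5-methylfuran-2-yl, 5-ethylfuran-2-yl and 1,3-oxazol-2-yl all stayed within the scatter, so these steps are the first to show that the number responds to the group on this carbon, with compound 4 the weakest inhibitor of the four. Nothing available here explains why this group behaves differently from the other three.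

The change from compound 3 to compound 4 brings in a ring sulfur in place of the ring oxygen and a methyl group together, so the compounds shown leave open which of the two goes with the step, a question that 1,3-thiazol-2-yl without the methyl or 4-methyl-1,3-oxazol-2-yl would address. They also leave open how this position responds to a group of another kind, such as a phenyl ring or an amine.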